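The source may hold more compounds than are shown below. What is called first, only, known or untested is meant among the compounds shown, and "the series" means these compounds.

Compounds measured so far:

Compound 1, `FC(F)(F)c1ccccc1-c1ccc2[nH]c(C3=NC4(CCCCC4)CO3)nc2c1`, in a functional assay on HEK293 cells for antagonist activity at transient receptor potential M8 protein (Canis lupus familiaris), read by FLIPR and calcium flux (a higher number here means a weaker inhibitor, a lower number a stronger inhibitor), compound 1 gives 6 nM.
Compound 2, `Fc1ccccc1-c1ccc2[nH]c(C3=NOC4(CCCCC4)C3)nc2c1`, in this assay compound 2 gives 2.9 nM.

Of these two numbers, compound 2 holds the lower one, and the gap to compound 1 is beyond the usual scatter of repeated measurements, so compound 2 is the stronger inhibitor of the pair. The two compounds differ in several places at once, so nothing can be said about any single change between them.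

Compound 3, `Fc1cccc(OC(F)(F)F)c1-c1ccc2[nH]c(C3=NOC4(CCCCC4)C3)nc2c1`, shares the core and the spiro-fused ring system of compound 2 and differs from it in a single place: trifluoromethoxy in place of hydrogen on an aromatic carbon. Within the data shown here, no pair of measured compounds shows what such a change does in this assay, so there is no measured step to lean on. With compound 2 already among the lowest numbers seen, a large further drop seems unlikely; a step of modest size, if any, toward a somewhat higher number is the more cautious expectation for a 1.7-fold higher number from compound 2 to compound 3 (0.24 log units; within the scatter). Compound 3 is therefore expected to give about 5 nM in this assay, within a range from 1.5 nM to 20 nM.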

Compound 3, half-maximal inhibitory concentration: 0.8 nM
The estimate for compound 3 lay 6.3-fold (0.80 log units) above the measured number, outside the stated range (below it).
By their numbers in this assay, from the lowest: compound 3; then compound 2; then compound 1.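

In this assay, putting trifluoromethoxy in place of hydrogen on an aromatic carbon, ortho to a large group and meta to a fluoro group, gives a 3.6-fold lower number from compound 2 to compound 3 (0.56 log units; beyond the scatter) and so moves the number further than repeated measurements usually scatter. This is the only step shown in which just one place changes, and it shows that this position accepts a group of five heavy atoms with no loss of inhibition; the number in fact falls. No measurement among those shown gives a reason for this fall.

From the compounds shown here alone, with a single step at this position, it remains open whether the fall belongs to trifluoromethoxy itself or would also come with other groups there, such as a methoxy group, a chlorine atom or an amine. Among these compounds, it is also open whether the same change would lower the number on the different core of compound 1, since only one core carries this change here, and one step cannot show how far the effect extends.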